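Propoxy in place of 2-methoxyethoxy: notes on the series

The compounds below may be only part of what the source reports. "The series", "measured", "known", "first", "only" and "open" are said of these compounds alone.

In a functional assay on KMS-11 cells (Homo sapiens), read by neutral red uptake, with a stated time of 48 h (on this read-out lower numbers stand for stronger inhibition and higher numbers for weaker inhibition), compound 1 (`COc1ccnc2[nH]cc(-c3ccnc(SC)n3)c12`) gives > 20000 nM as a limit and not a number. Compound 2 (`COCCOc1ccnc2[nH]cc(-c3ccnc(N)n3)c12`) gives > 20000 nM as a limit too. Compound 2 therefore stands at the limit of > 20000 nM in this assay, at which 2 of the 2 values shown sit, and has no number of its own. Compound 3 (`CCCOc1ccnc2[nH]cc(-c3ccnc(N)n3)c12`) differs from compound 2 by methyl in place of methoxy on a saturated chain carbon, two bonds along the chain from an oxygen on an aromatic ring with methyl in place of methoxy on a saturated chain carbon, two bonds along the chain from an oxygen on an aromatic ring, so 2-methoxyethoxy becomes propoxy. Going by the values given here, no measured step gives a size for this change. Taking compound 2 and its limit > 20000 nM as the reference, any move in this assay is expected towards stronger inhibition, and a second limit remains quite possible. The expected change is an at least 2.0-fold lower number from compound 2 to compound 3 (0.30 log units; that floor lies within the scatter) on thin support. For compound 3 the estimated value is 10000 nM with an expected range from 1000 nM to 20000 nM in this read-out.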

Compound 3, half-maximal inhibitory concentration: 40 nM
Beside the measured number, compound 3's estimate is 250-fold (2.40 log units) above it; the measured number lies below the stated range.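

Methyl in place of methoxy on a saturated chain carbon, two bonds along the chain from an oxygen on an aromatic ring, gives an at least 500-fold lower number from compound 2 to compound 3 (2.69 log units; beyond the scatter) in this assay. Going by these compounds alone, the earlier compounds gave limits only, so this is the first sign that this position can decide between a limit and a measured number, and that 2-methoxyethoxy to propoxy alone is enough to do so. The size of the step is a floor and not a number, because compound 2 has only a limit: the limit of > 20000 nM in this assay, at which 2 of the 3 values shown sit.

Open, from the compounds shown here alone, is whether the propoxy chain itself or the removal of the chain oxygen matters, which an ethoxy group, a butoxy group or a terminal amine on the chain would help to separate. Also open, going by these compounds, is whether the same change holds on the core of compound 1.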